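The compounds below may be only part of what the source reports. "The series", "measured", "known", "first", "only" and "open" are said of these compounds alone.

Going by the values given here, compound 2 `Nc1ncnc2c1ncn2[C@@H]1O[C@H](CN(CCCc2cccc3ccccc23)CC[C@H](N)C(=O)O)[C@@H](O)[C@H]1O` stands highest of the two numbers measured so far: in an assay on cells for inhibition of Nicotinamide N-methyltransferase (Homo sapiens), read by fluorescence and coupled enzyme assay, with a stated time of 10 min, in the presence of a further agent that is not named here (a lower number here means a stronger inhibitor, a higher number a weaker inhibitor), compound 2 gives 11800 nM, while compound 1 `Cc1ccc(CCCN(CC[C@H](N)C(=O)O)C[C@H]2O[C@@H](n3cnc4c(N)ncnc43)[C@H](O)[C@@H]2O)cc1C(N)=O` gives 51 nM. Compound 3 `COC(=O)c1cccc(CCCN(CC[C@H](N)C(=O)O)C[C@H]2O[C@@H](n3cnc4c(N)ncnc43)[C@H](O)[C@@H]2O)c1` differs from compound 2 by 3-(methoxycarbonyl)phenyl in place of naphthalen-1-yl on a saturated chain carbon, three bonds along the chain from an amine nitrogen. Among the compounds with values here, the one measured step that bears on this, a 230-fold higher number from compound 1 to compound 2 (2.36 log units; beyond the scatter), went the opposite way, replacing a single substituted ring with the naphthyl group; compound 3 returns to a single substituted ring, though carrying an ester rather than the amide of compound 1. A large fall in the number is therefore expected for compound 3, a 59-fold lower number from compound 2 to compound 3 (1.77 log units; beyond the scatter), with an estimate of 200 nM and a range from 40 nM to 1500 nM.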

Compound 3, inhibition constant: 28000 nM
Beside the measured number, compound 3's estimate is 140-fold (2.15 log units) below it; measured number above the stated range.
By their numbers in this assay, from the lowest: compound 1; then compound 2; then compound 3.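

Carrying a single ring at this position does not by itself restore a low number: 3-(methoxycarbonyl)phenyl in place of naphthalen-1-yl gives a 2.4-fold higher number from compound 2 to compound 3 (0.38 log units; beyond the scatter). What the ring carries matters far more, with a 550-fold higher number from compound 1 to compound 3 (2.74 log units; beyond the scatter), although that step swaps the amide and methyl of compound 1 together for the ester. Nothing available explains these results. Still open, from the compounds shown here alone, is whether the amide alone, without the methyl, keeps the low number of compound 1. Going by these compounds, it is also open how a carboxylic acid in place of the ester would compare with compound 3.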